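The source may hold more compounds than are shown below. What is called first, only, known or untested is meant among the compounds shown, and "the series" means these compounds.

For the measured compounds named here, compound 2 `Cc1ccccc1C(=O)Nc1ccc(S(=O)(=O)NC2CCN(C(=O)CN)CC2)c2ccccc12` holds the lowest of the two numbers so far in an assay on L1.2 cells for binding affinity to C-C chemokine receptor type 8 (Homo sapiens) (a higher number here means a weaker inhibitor, a lower number a stronger inhibitor), where compound 2 gives 4.1 nM; the nearest is compound 1 `Cc1ccccc1C(=O)Nc1ccc(S(=O)(=O)NC2CCN(C(=O)C3CCCC3)CC2)c2ccccc12`, and in this assay compound 1 gives 9.1 nM. Going by the values given here, the one step between them, a 2.2-fold lower number from compound 1 to compound 2 (0.35 log units; beyond the scatter), came with aminomethyl in place of cyclopentyl on the carbonyl carbon. Compound 3 `Cc1ccccc1C(=O)Nc1ccc(S(=O)(=O)NC2CCN(C(=O)CCCCN)CC2)c2ccccc12` differs from compound 2 by 3-aminopropyl in place of amino on a saturated chain carbon bound to a carbonyl carbon, so the amino group stays while the chain carrying it grows. Among the compounds with values here, no measured step tests a change of chain length alone; the only step available, a 2.2-fold lower number from compound 1 to compound 2 (0.35 log units; beyond the scatter), shows merely that an amine-bearing group in place of cyclopentyl gave a lower number. Compound 3 is therefore expected to stay close to its parent, with an expected step of a 1.5-fold higher number from compound 2 to compound 3 (0.17 log units; within the scatter). For compound 3 the estimate in this assay is 6 nM, in a range from 2.5 nM to 15 nM.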

Compound 3, inhibition constant: 199 nM
Beside the measured number, compound 3's estimate is 33-fold (1.52 log units) below it; the whole stated range lies below it.
By their numbers in this assay, from the lowest: compound 2; then compound 1; then compound 3.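

In this assay, this position proved highly sensitive to the length of the chain on the carbonyl carbon: with the amino group retained, going from aminomethyl to 4-aminobutyl gave a 49-fold higher number from compound 2 to compound 3 (1.69 log units; beyond the scatter), so an amine-bearing group does not by itself secure a low number. The longer chain also compared poorly with cyclopentyl on the carbonyl carbon, with a 22-fold higher number from compound 1 to compound 3 (1.34 log units; beyond the scatter), so the advantage seen for aminomethyl did not extend to 4-aminobutyl. Nothing shown bears on the reason for this rise in the number.

The compounds shown leave open whether the number climbs steadily with chain length or jumps at one point, as 2-aminoethyl or 3-aminopropyl on the carbonyl carbon could show. They also leave open whether a plain butyl chain, without the amine, would behave like 4-aminobutyl.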